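Trimming an Ethoxy Group: From Compound 3 to Compound 4

The source may hold more compounds than are shown below. What is called first, only, known or untested is meant among the compounds shown, and "the series" means these compounds.

All numbers below come from an assay on BTI-TN-5B1-4 cells for inhibition of Amine oxidase [flavin-containing] B (Homo sapiens), read by fluorescence and Amplex Red, using microsomes, with a stated time of 30 min; on this read-out higher numbers stand for weaker inhibition and lower numbers for stronger inhibition.

Compound 1 `C#CCOc1ccc(-c2cc(-c3ccc(OCC#C)cc3)nc(-c3ccccc3)n2)cc1` gives 12300 nM.
Compound 2 `C#CCOc1ccc(-c2cc(-c3ccc(OCC#C)c(OCC)c3)nc(-c3ccccc3)n2)cc1` gives 29000 nM.
Compound 3 `C#CCOc1ccc(-c2cc(-c3ccc(OCC#C)c(OCC)c3)nc(N)n2)cc1` gives 14000 nM.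

Compound 3 holds the second highest number of the three. It sits within the scatter of compound 1, while the step of a 2.1-fold lower number from compound 2 to compound 3 (0.32 log units; beyond the scatter) lies beyond it.

Compound 4 `C#CCOc1ccc(-c2cc(-c3ccc(OCC#C)c(OC)c3)nc(N)n2)cc1` differs from compound 3 by hydrogen in place of methyl on a saturated chain carbon bound to an oxygen on an aromatic ring. Among the measured compounds shown here, no measured step trims an ethoxy in this way; the closest is a 2.4-fold higher number from compound 1 to compound 2 (0.37 log units; beyond the scatter), a modest rise when ethoxy entered for hydrogen. Cutting one carbon from that ethoxy is a smaller change, so the expected step of a 1.3-fold lower number from compound 3 to compound 4 (0.10 log units; within the scatter) is small, probably within the scatter, leaning toward a slightly lower number. Compound 4 is therefore expected near 11000 nM, between 5500 nM and 22000 nM.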

Compound 4, half-maximal inhibitory concentration: 20000 nM
The estimate for compound 4 lay 1.8-fold (0.26 log units) below the measured number, within the range that was stated.
By their numbers in this assay, from the lowest: compounds 1, 3, 4 and 2 (each within the scatter of the next, the first and the last beyond it).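

Shortening ethoxy to methoxy at this place gives a 1.4-fold higher number from compound 3 to compound 4 (0.15 log units; within the scatter), so removing this methyl leaves no change that can be told from the scatter. The earlier step showed only ethoxy entering in place of hydrogen, on a core carrying phenyl rather than amino; this one shows that, with amino present, the length of this small chain can shift by one carbon without a clear effect on the number. Nothing available explains this result.

On these data alone, whether a longer chain such as propoxy or butoxy, or a hydroxyl, would move the number beyond the scatter remains open. So does whether the same trim would behave alike with phenyl in place of amino.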